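Swapping Chloro for Fluoro in a Dithiazoline Chromone Series

This account rests on a few compounds, and the source may have more. Where it says the series, first, only, none or still open, it means among the compounds named here.

Compound 1 `O=c1c(C2N=C(c3ccccc3)SS2)coc2ccc(Cl)cc12`: 10000 nM
Compound 2 `O=c1c(C2N=C(c3ccccc3)SS2)coc2cc(Cl)c(Cl)cc12`: 58000 nM
Compound 3 `O=c1c(C(=S)Nc2ccccc2)coc2cc(Cl)c(Cl)cc12`: 89900 nM

In a functional assay on IMR-32 cells (Homo sapiens) for inhibition, read by sulforhodamine B assay, with a stated time of 48 h (a higher number here means a weaker inhibitor, a lower number a stronger inhibitor), compound 2 stands second highest of the three values; its nearest neighbour, compound 3, lies within the scatter, while compound 1 sits well below. The unmeasured compound 4 `O=c1c(C2N=C(c3ccccc3)SS2)coc2cc(Cl)c(F)cc12` differs from compound 2 by fluoro in place of chloro on an aromatic carbon. Going by the values given here, the only measured step that bears on this place is a 5.8-fold higher number from compound 1 to compound 2 (0.76 log units; beyond the scatter), where hydrogen became chloro. A fluoro group is smaller than chloro but larger than hydrogen, so the step from compound 2 to compound 4 is expected to fall back toward compound 1, yet only partly; the expected step is a 2.3-fold lower number from compound 2 to compound 4 (0.37 log units; beyond the scatter). Compound 4 is therefore estimated at 25000 nM, with a range from 8000 nM to 80000 nM.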

Compound 4, half-maximal inhibitory concentration: 56800 nM
Estimate against measurement, compound 4: 2.3-fold (0.36 log units) below; low and high end bracket the measured number.
By their numbers in this assay, from the lowest: compound 1; then compounds 4, 2 and 3 (each within the scatter of the next).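

In this assay, exchanging one halogen for the other at this place gives no readable change: a 1.0-fold lower number from compound 2 to compound 4 (0.01 log units; within the scatter). The earlier step, a 5.8-fold higher number from compound 1 to compound 2 (0.76 log units; beyond the scatter), showed that adding a chloro group can shift the number beyond the scatter, whereas this pair shows that, with a chloro group ortho to it, fluoro and chloro cannot be told apart at this place. No measurement shown here accounts for this result. On these data alone, it remains open whether a larger or different group at this place, such as an amine, a methoxy group or a carboxylic acid, would shift the number.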